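Swapping ethyl for cyclopropylmethyl on compound 2

The compounds below may be only part of what the source reports. "The series", "measured", "known", "first", "only" and "open" are said of these compounds alone.

In a functional assay on BT-483 cells (Homo sapiens) for cytotoxicity, read by MTT assay, with a stated time of 24 h (a lower number here means a stronger inhibitor, a higher number a weaker inhibitor), compound 1 `CCNc1cc(-c2ccc(NC(=O)Nc3cccc(Cl)c3)cc2C)ccn1` gives 16600 nM and compound 2 `CCNc1cc(-c2ccc(NC(=O)Nc3cccc(Cl)c3)cc2C(F)(F)F)ccn1` gives 13300 nM. These two stand level, with trifluoromethyl in place of methyl on an aromatic carbon giving a 1.2-fold lower number from compound 1 to compound 2 (0.10 log units; within the scatter). Compound 3 `CCNc1cc(-c2ccc(NC(=O)Nc3cccc4ccccc34)cc2C(F)(F)F)ccn1` gives > 30000 nM, which is a limit of the assay and not a number. Naphthalen-1-yl in place of 3-chlorophenyl on an amide-type nitrogen gives an at least 2.2-fold higher number from compound 2 to compound 3 (0.35 log units; beyond the scatter).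

Compound 4 `O=C(Nc1cccc(Cl)c1)Nc1ccc(-c2ccnc(NCC3CC3)c2)c(C(F)(F)F)c1` differs from compound 2 in one place: cyclopropyl in place of methyl on a saturated chain carbon bound to a nitrogen on an aromatic ring. This is cyclopropyl in place of methyl on a saturated chain carbon bound to a nitrogen on an aromatic ring, so ethylamino becomes (cyclopropylmethyl)amino. Neither measured step changes this chain, so both bear on it only loosely, and neither gives a size or direction to carry over. No step beyond the scatter is therefore expected in this assay. The estimated step is a 1.1-fold lower number from compound 2 to compound 4 (0.04 log units; within the scatter). For compound 4 the expected value is 12000 nM, with an estimated range from 5500 nM to 28000 nM.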

Compound 4, half-maximal inhibitory concentration: > 30000 nM
Compound 4: only a limit was reported (the forecaster's own chance of this, stated with the estimate: 15%); middle value at least 2.5-fold (0.39 log units) from the limit.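

Within the data shown here, the ethylamino chain, which no earlier step touched, turns out to matter in this assay: cyclopropyl in place of methyl on this saturated chain carbon gives an at least 2.2-fold higher number from compound 2 to compound 4 (0.35 log units; beyond the scatter). Compound 4 gives > 30000 nM, which is a limit of the assay and not a number. How large the step really is therefore cannot be read, and this is the second change among those shown to end at the same limit: the limit of > 30000 nM in this assay, at which 2 of the 4 values shown sit.

The compounds shown leave open whether the added carbons or the three-membered ring accounts for this step. A straight butyl chain on the same nitrogen would bear on that question, and a plain amino group in place of ethylamino would show whether a shorter substituent moves the number the other way.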